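Ester side-chain variation in the shared core: working notes

A few compounds are considered here, and "the series" means these few. Any claim that something is new, unique, unknown or untested is made for them only; others in the source may bear on it.

Measured compounds in a functional assay on SK-BR-3 cells (Homo sapiens) for antiproliferative activity, read by MTT assay, with a stated time of 72 h; a higher number here means a weaker inhibitor, a lower number a stronger inhibitor:
- compound 1, `C=C(C)CCOC(=O)C[C@@H]1C(C(=O)OC)=CO[C@@H](O[C@@H]2O[C@H](CO)[C@@H](O)[C@H](O)[C@H]2O)/C1=C/C`: compound 1 reaches only the assay limit > 15000 nM, a limit and not a number
- compound 2, `C/C=C1/[C@H](O[C@@H]2O[C@H](CO)[C@@H](O)[C@H](O)[C@H]2O)OC=C(C(=O)OC)[C@H]1CC(=O)OCCc1ccccc1`: compound 2 gives 11000 nM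

Compound 2 holds the only number shown in this assay; the further value is a limit. Among the compounds with values here, the single measured step, an at least 1.3-fold lower number from compound 1 to compound 2 (0.13 log units; that floor lies within the scatter), rests on phenyl in place of 1-methylethenyl on a saturated chain carbon, two bonds along the chain from an oxygen next to a carbonyl group, and the floor of that step lies within the scatter, so the two ester side chains are not distinguished by the numbers. Compound 1 contributes only (the limit of > 15000 nM in this assay, at which 1 of the 2 values shown sits).

The next compound, compound 3, `C/C=C1/[C@H](O[C@@H]2O[C@H](CO)[C@@H](O)[C@H](O)[C@H]2O)OC=C(C(=O)OC)[C@H]1CC(=O)OCc1ccco1`, differs from compound 2 by furan-2-yl in place of benzyl on a saturated chain carbon bound to an oxygen next to a carbonyl group. No measured step bears directly on this change, and the one step shown is at most modest. The expectation is therefore a step of a 1.1-fold higher number from compound 2 to compound 3 (0.04 log units; within the scatter), not beyond the scatter, in either direction. For compound 3 the estimate in this assay is 12000 nM, expected to fall between 5000 nM and 30000 nM.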

Compound 3, half-maximal inhibitory concentration: > 15000 nM
Compound 3 was reported as a limit; the forecaster's own chance of this, stated with the estimate: 40%; middle value at least 1.2-fold (0.09 log units) away from the limit.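

At this position, on a saturated chain carbon bound to an oxygen next to a carbonyl group, furan-2-yl in place of benzyl gives an at least 1.3-fold higher number from compound 2 to compound 3 (0.13 log units; that floor lies within the scatter), so the floor of this step does not separate the two side chains in this assay. Compound 3 adds a second case with an aromatic ring in the ester side chain, and it still reports a limit and not a number, so an aromatic ring there does not by itself secure a measurable value. The step between compound 1 and compound 3 cannot be read, and the set as a whole stays largely at the edge of the assay range: the limit of > 15000 nM in this assay, at which 2 of the 3 values shown sit.

As far as these compounds go, whether any ester side chain can move the shared core well away from that limit stays open. Within the data shown here, compound 2 at 11000 nM is the only number to compare against. A side chain ending in an amine or a carboxylic acid, or a longer chain carrying the phenyl ring, would show whether the value of compound 2 depends on this position at all.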